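Series notes: chloro to amino and cell toxicity

A few compounds are considered here, and "the series" means these few. Any claim that something is new, unique, unknown or untested is made for them only; others in the source may bear on it.

Compound 1 `COC(=O)c1ccc(NCc2cncn2Cc2ccccc2Cl)cc1-c1ccccc1` serves as the reference point of these notes. In a toxicity assay on NIH3T3 cells (Mus musculus) for cytotoxicity, read by resazurin assay (a lower number here means that less compound is needed, a higher number that more compound is needed for the effect), compound 1 gives 10000 nM. Compound 2 `c1ccc(-c2ccc(Cn3cncc3CNc3cccc(-c4ccccc4)c3)cc2)cc1` gives 10000 nM in this assay, so compound 1 stands level with compound 2 at the digits shown, a difference within the usual scatter. Compound 3 `Cc1cccc(-c2cccc(NCc3cncn3Cc3ccccc3)c2)c1C` gives only a limit of the assay, > 1000 nM in this assay. (the limit of > 1000 nM in this assay, at which 1 of the 3 values shown sits), this being the one limit among the three values recorded. For the measured compounds named here, no measured pair differing in a single place is at hand, so no step size is known from the data themselves.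

Compound 4 `COC(=O)c1ccc(NCc2cncn2Cc2ccccc2N)cc1-c1ccccc1` is the next compound in view; it differs from compound 1 by amino in place of chloro on an aromatic carbon. Since compound 1 gives 10000 nM and compound 2 gives 10000 nM, the expected step of no change at the digits printed from compound 1 to compound 4 (within the scatter) is none beyond the scatter. Compound 4 is therefore estimated to give 10000 nM in this assay, within a range from 4000 nM to 25000 nM, with a fair chance that only a limit is reported.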

Compound 4, half-maximal effective concentration: 25000 nM
Beside the measured number, compound 4's estimate is 2.5-fold (0.40 log units) below it; the range from low to high includes it.
By their numbers in this assay, from the lowest: compounds 1 and 2 (each within the scatter of the next); then compound 4.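

In this assay, for the compounds shown here, 2-aminobenzyl in place of 2-chlorobenzyl gives a 2.5-fold higher number from compound 1 to compound 4 (0.40 log units; beyond the scatter), the first step that can be read across a single change. The position on the aromatic carbon, ortho to a large group, therefore responds to substitution: with amino there, which carries the hydrogen-bond donor and acceptor that chloro lacks, more compound is needed for the effect. Nothing in the data shown accounts for this step.

Open, from the compounds shown here alone, is whether the step is particular to amino or would also appear with another group at this position, such as hydroxyl, methoxy or fluoro. Going by these compounds alone, also open is whether the same change would give a similar step on other compounds, as this single pair is the only reading of it.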